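Fluoro to amino on the aryl group of compound 2

A few compounds are considered here, and "the series" means these few. Any claim that something is new, unique, unknown or untested is made for them only; others in the source may bear on it.

Measured in a functional assay on IMR-32 cells (Homo sapiens) for inhibition, with a stated time of 48 h, tested at 50 uM; on this read-out higher numbers stand for more inhibition of growth at the one concentration tested and lower numbers for less inhibition of growth:
- compound 1 `COc1ccc(/C=C/[C@@](C)(/C=C/c2ccc(O)cc2)CCC=C(C)C)cc1`: 6%
- compound 2 `CC(C)=CCC[C@](C)(/C=C/c1ccc(O)cc1)/C=C/c1ccc(F)cc1`: 37%

Of the two measured compounds, compound 2 stands highest at 37%, with compound 1 the nearest at 6%. The next compound to consider is compound 3 `CC(C)=CCC[C@@](C)(/C=C/c1ccc(N)cc1)/C=C/c1ccc(O)cc1`, which has amino in place of fluoro on an aromatic carbon, para to a large group: amino in place of fluoro on an aromatic carbon.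

Among the measured compounds shown here, only one measured step bears on this change: a number 31 percentage points higher from compound 1 to compound 2 (beyond the scatter), a large step with fluoro in place of methoxy on an aromatic carbon. For the measured compounds named here, no measured compound carries amino, so this step gives only indirect guidance. As the higher number came with fluoro in a number 31 percentage points higher from compound 1 to compound 2 (beyond the scatter), removing fluoro is expected to lower the number in this assay, though probably by less than that step.

The expected step is a number 15 percentage points lower from compound 2 to compound 3 (beyond the scatter), and this estimate remains uncertain with a single step behind it. For compound 3, the estimated value is 22%, with an expected range of 5% to 48%.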

Compound 3, percent growth inhibition at one concentration: 28%
Estimate against measurement, compound 3: 6 percentage points below; measured number inside the range.
By their numbers in this assay, from the lowest: compound 1; then compounds 3 and 2 (each within the scatter of the next).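

In this assay the change from 4-fluorophenyl to 4-aminophenyl gives a number 9 percentage points lower from compound 2 to compound 3 (within the scatter) and so leaves the read-out unresolved between these two groups, even though amino brings a hydrogen-bond donor and a hydrogen-bond acceptor that fluoro does not. Methoxy now stands apart at this place, on an aromatic carbon para to a large group: besides the earlier fluoro step, amino gives a number 22 percentage points higher from compound 1 to compound 3 (beyond the scatter) and thus a second replacement of methoxy that lies beyond the scatter, with no listed compound going against this within the three compounds. No measurement bearing on the reason for these differences is available.

Still open, from the compounds shown here alone, is whether a chloro, nitrile or acetamido group at this place would fall with fluoro and amino or with methoxy, and three groups on one aryl ring are too few to rank substituents more widely. Also open, going by these compounds, is whether the separation of methoxy from the other two groups would persist across a range of concentrations, as each compound here is described by growth inhibition at one concentration only.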